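A few compounds are considered here, and "the series" means these few. Any claim that something is new, unique, unknown or untested is made for them only; others in the source may bear on it.

Among the compounds with values here, in a functional assay on MCF7 cells (Homo sapiens) for inhibition, read by MTT assay, with a stated time of 72 h (a higher number here means a weaker inhibitor of growth, a lower number a stronger inhibitor of growth), compound 2, `O=S(=O)(NCCCNCc1ccc(Br)cc1)c1cc(C(F)(F)F)cc(C(F)(F)F)c1`, gives 1900 nM, the lowest of the two numbers so far; the only other point, compound 1, `O=S(=O)(NCCCNCc1ccccc1Cl)c1cc(C(F)(F)F)cc(C(F)(F)F)c1`, gives 8800 nM. Within the data shown here, the one step measured, a 4.6-fold lower number from compound 1 to compound 2 (0.67 log units; beyond the scatter), swaps one halogenated phenyl for another on the saturated chain carbon bound to the amine nitrogen. Compound 3, `COc1cccc(CNCCCNS(=O)(=O)c2cc(C(F)(F)F)cc(C(F)(F)F)c2)c1`, changes the same position differently: 3-methoxyphenyl in place of 4-bromophenyl on a saturated chain carbon bound to an amine nitrogen. Among the measured compounds shown here, no measured step covers a methoxy-bearing phenyl at this place, so the step from compound 1 to compound 2 offers only a sense of scale: changes of this kind on the shared core have moved this assay by a modest amount. For compound 3 the step is therefore estimated as a 1.6-fold higher number from compound 2 to compound 3 (0.20 log units; within the scatter), direction uncertain and close to the scatter. Compound 3 is expected to give 3000 nM in this assay, within 1200 nM to 8000 nM.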

Compound 3, concentration for 50% growth inhibition: 2400 nM
Compound 3: the middle estimate sits 1.3-fold (0.10 log units) above what was measured; the measured number falls inside the stated range.
By their numbers in this assay, from the lowest: compounds 2 and 3 (each within the scatter of the next); then compound 1.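

In this assay, a phenyl bearing a methoxy group and one bearing a bromine cannot be told apart at this place on a saturated chain carbon bound to an amine nitrogen: a 1.3-fold higher number from compound 2 to compound 3 (0.10 log units; within the scatter). The 2-chlorophenyl group now stands apart from a group without halogen as well: a 3.7-fold lower number from compound 1 to compound 3 (0.56 log units; beyond the scatter). Of the three groups shown, 2-chlorophenyl alone is separated from the others beyond the scatter, and no evidence on hand bears on why these numbers fall as they do.

Still open, from the compounds shown here alone, is whether the identity of the substituent or its place on the ring separates 2-chlorophenyl from the others, a question that 4-chlorophenyl and 2-methoxyphenyl at this position would address. Also open, going by these compounds, is how a pyridine ring or a carboxylic acid-bearing phenyl would read here.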